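The compounds below may be only part of what the source reports. "The series", "measured", "known", "first", "only" and "open" are said of these compounds alone.

Compound 1 `N#Cc1c(-c2ccc(O)cc2)c(C#N)c(=O)n(/N=C/c2cn(-c3ccccc3)nc2-c2ccccc2)c1N` gives 110 ug/mL in an ADME assay on NIH3T3 cells (Mus musculus) for cytotoxicity, read by MTT assay; a higher number here means a weaker inhibitor, a lower number a stronger inhibitor.
Compound 2 `N#Cc1c(-c2cccc(Cl)c2)c(C#N)c(=O)n(/N=C/c2cn(-c3ccccc3)nc2-c2ccccc2)c1N` gives 52 ug/mL in this assay.
Compound 3 `N#Cc1c(-c2ccc(F)cc2)c(C#N)c(=O)n(/N=C/c2cn(-c3ccccc3)nc2-c2ccccc2)c1N` reaches only a limit of the assay, > 200 ug/mL, in this assay.

Among the two numbers actually obtained, compound 1 stands highest, so it is the weaker of the two at harming the cells; the nearest is a 2.1-fold lower number from compound 1 to compound 2 (0.33 log units; beyond the scatter). Compound 3 sits at the limit of > 200 ug/mL in this assay, at which 1 of the 3 values shown sits, so no number is known for it.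

Compound 4 `COc1ccc(-c2c(C#N)c(N)n(/N=C/c3cn(-c4ccccc4)nc3-c3ccccc3)c(=O)c2C#N)cc1` has not yet been measured in this assay. It differs from compound 1 in one place: methyl in place of hydrogen on an oxygen on an aromatic ring, which reads, cut one bond further out, as hydroxy to methoxy, or 4-hydroxyphenyl to 4-methoxyphenyl. For the measured compounds named here, two measured steps bear on this. The closest is the change at the same spot, fluoro in place of hydroxy, which gave an at least 1.8-fold higher number from compound 1 to compound 3 (0.25 log units; that floor lies within the scatter). The other, swapping the whole 4-hydroxyphenyl for 3-chlorophenyl, gave a 2.1-fold lower number from compound 1 to compound 2 (0.33 log units; beyond the scatter). Neither points firmly in one direction, so the expected step in this assay is one that stays within the scatter, perhaps leaning upward.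

Compound 4 is therefore expected to show about 130 ug/mL in this assay, somewhere between 60 ug/mL and 280 ug/mL.
That estimate means an expected step of a 1.2-fold higher number from compound 1 to compound 4 (0.07 log units; within the scatter).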

Compound 4, half-maximal inhibitory concentration: 50 ug/mL
Beside the measured number, compound 4's estimate is 2.6-fold (0.41 log units) above it; the whole stated range lies above it.
By their numbers in this assay, from the lowest: compounds 4 and 2 (each within the scatter of the next); then compound 1. At a limit, above all of these: compound 3.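

Adding a methyl to the oxygen of the 4-hydroxyphenyl is enough to shift the result in this assay, giving a 2.2-fold lower number from compound 1 to compound 4 (0.34 log units; beyond the scatter), so this small change makes the compound more harmful to the cells. Putting 4-methoxyphenyl in place of 3-chlorophenyl gives a 1.0-fold lower number from compound 2 to compound 4 (0.02 log units; within the scatter), so these two compounds cannot be told apart here, even though their groups differ. Methoxy in place of fluoro gives an at least 4.0-fold lower number from compound 3 to compound 4 (0.60 log units; beyond the scatter), and this step starts from a limit rather than a number: the limit of > 200 ug/mL in this assay, at which 1 of the 4 values shown sits.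

The compounds shown leave open whether a longer chain on the oxygen, such as ethoxy, would lower the number further or raise it again. They also leave open how an amine or a carboxylic acid in place of the hydroxy would read.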